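The source may hold more compounds than are shown below. What is called first, only, known or untested is meant among the compounds shown, and "the series" means these compounds.

Two compounds share the same core and differ at a single saturated ring carbon. Compound 1 `O=C1C[C@@H]2CCCC[C@@H]2[C@H]1/C=C/c1ccc(-c2cccc(F)c2)cn1` carries a carbonyl there, while compound 2 `OC1C[C@@H]2CCCC[C@@H]2[C@H]1/C=C/c1ccc(-c2cccc(F)c2)cn1` carries a hydroxy group. In an assay on cell membranes for displacement of a labelled ligand from proteinase-activated receptor 1 (Homo sapiens), read by scintillation counting, with a stated time of 60 min (a higher number here means a weaker inhibitor, a lower number a stronger inhibitor), compound 1 gives 1100 nM, and in this assay compound 2 gives 220 nM. For the measured compounds named here, of the two numbers known so far, compound 2 has the lowest, and its gap to compound 1 is beyond the usual scatter, so compound 2 is the stronger inhibitor of the pair.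

Compound 3 `COC1C[C@@H]2CCCC[C@@H]2[C@H]1/C=C/c1ccc(-c2cccc(F)c2)cn1` has not yet been measured. It differs from compound 2 in one place: methyl in place of hydrogen on an oxygen on a saturated carbon. Going by the values given here, no step between measured compounds covers this kind of change, so there is no direct guide. What the two known values do show is that compound 1, which has no hydroxy group, gives the higher number. The step expected here, a 2.3-fold higher number from compound 2 to compound 3 (0.36 log units; beyond the scatter), points toward a weaker inhibitor, by an amount that may exceed the scatter. In this assay compound 3 is expected to give 500 nM, with a likely range from 150 nM to 1600 nM.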

Compound 3, half-maximal inhibitory concentration: 67 nM
Compound 3: the middle estimate sits 7.5-fold (0.87 log units) above what was measured; the whole stated range lies above it.
By their numbers in this assay, from the lowest: compound 3; then compound 2; then compound 1.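

Putting methyl in place of hydrogen on this oxygen, turning hydroxy into methoxy, gives a 3.3-fold lower number from compound 2 to compound 3 (0.52 log units; beyond the scatter) in this assay, a step beyond the usual scatter. For the compounds shown here, compounds 1 and 2 alone showed only that a hydroxy group at this saturated ring carbon gives a lower number than a carbonyl, which left open whether the hydrogen on that oxygen was needed; compound 3 has no such hydrogen and still gives the lowest number of the three, so a low number does not depend on it. The data offer no measurement that explains why the methoxy compound gives the lower number.

Going by these compounds alone, only one group on this oxygen has been compared with hydrogen, so it remains open whether the trend continues with an ethyl group or a longer chain, or reverses with them. Also open, going by these compounds, is how an amine or a fluorine atom in place of the oxygen at this ring carbon would compare, and whether the gain from methoxy would carry over to compounds that differ elsewhere on the shared core.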